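A Fluoro Change on the Weaker of Two Inhibitors

The compounds below may be only part of what the source reports. "The series", "measured", "known", "first", "only" and "open" are said of these compounds alone.

In a functional assay on A549 cells (Homo sapiens) for inhibition, read by MTT assay, with a stated time of 72 h (a lower number here means a stronger inhibitor, a higher number a weaker inhibitor), compound 1 (`C=CC(=O)Nc1cc(Nc2nc3c(c(-c4cn(C)c5ccccc45)n2)CS(=O)(=O)CC3)c(OC)cc1N(C)CCN(C)C`) gives 8690 nM and holds the higher of the two measured numbers. Compound 2 (`COc1cc(N(C)CCN(C)C)c(NC(=O)C=C(C)C)cc1Nc1nc2c(c(-c3cn(C)c4ccccc34)n1)CS(=O)(=O)CC2`) gives 787 nM in this assay and is the stronger inhibitor of the pair. Among the compounds with values here, the single measured step (an 11-fold lower number from compound 1 to compound 2 (1.04 log units; beyond the scatter)) is large and comes from 2-methylprop-1-en-1-yl in place of vinyl on a carbonyl carbon.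

Compound 3 (`C=CC(=O)Nc1cc(Nc2nc3c(c(-c4cn(C)c5ccc(F)cc45)n2)CS(=O)(=O)CC3)c(OC)cc1N(C)CCN(C)C`) keeps the vinyl group of compound 1 and changes another part of the molecule. The change (fluoro in place of hydrogen on an aromatic carbon) is fluoro in place of hydrogen on an aromatic carbon, which turns 1-methyl-1H-indol-3-yl into 5-fluoro-1-methyl-1H-indol-3-yl. Within the data shown here, no measured pair tests this change. The step to compound 2 (an 11-fold lower number from compound 1 to compound 2 (1.04 log units; beyond the scatter)) lies at a different place, so its size does not carry over, and no clear direction can be drawn from it. Only a small shift within the scatter is therefore expected, and the expected step (a 1.2-fold lower number from compound 1 to compound 3 (0.09 log units; within the scatter)) stays close to the value of compound 1 (8690 nM) in this assay. For compound 3 the estimate is 7000 nM (expected range 3000 nM to 16000 nM) in this measurement.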

Compound 3, half-maximal inhibitory concentration: 4640 nM
The estimate for compound 3 lay 1.5-fold (0.18 log units) above the measured number, within the range that was stated.
By their numbers in this assay, from the lowest: compound 2; then compounds 3 and 1 (each within the scatter of the next).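

In this assay, within the data shown here, fluoro in place of hydrogen on an aromatic carbon gives the first reading at this position (a 1.9-fold lower number from compound 1 to compound 3 (0.27 log units; within the scatter)): with the vinyl group kept, the step stays within the usual scatter, so compound 3 cannot be told apart from compound 1 in this assay, and a single fluoro atom at this carbon, turning 1-methyl-1H-indol-3-yl into 5-fluoro-1-methyl-1H-indol-3-yl, shows no clear effect. The only step beyond the scatter among the compounds shown remains the one at the carbonyl carbon (an 11-fold lower number from compound 1 to compound 2 (1.04 log units; beyond the scatter)), so the two places examined so far read differently, though each rests on one pair alone. No evidence is at hand that bears on the size of the fluoro step.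

The compounds shown leave open whether fluoro at this carbon would read the same alongside the 2-methylprop-1-en-1-yl group of compound 2. They also leave open what a larger group at the same carbon, such as chloro, methoxy or an amine, would do to the number in this assay.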